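The source may hold more compounds than are shown below. What is called first, only, known or untested is meant among the compounds shown, and "the series" means these compounds.

Working notes on the series in a functional assay on MOLT-4 cells (Homo sapiens); a lower number here means a stronger inhibitor, a higher number a weaker inhibitor. For the measured compounds named here, compound 1 (`COc1cc(NC(C)CCCNC(=O)NCCCCCO)c2ncccc2c1`) gives 61000 nM, the only actual number so far. Compound 2 (`COc1cc(NC(C)CCCNC(=O)NC(CO)(CO)CO)c2ncccc2c1`) gives only a limit of the assay, > 100000 nM. Compound 3 (`COc1cc(NC(C)CCCNC(=O)N(CCO)CCO)c2ncccc2c1`) also gives only a limit, > 100000 nM. Compound 4 (`CCOC(=O)NCCCC(C)Nc1cc(OC)cc2cccnc12`) carries ethoxy in place of bis(2-hydroxyethyl)amino on a carbonyl carbon. Two measured steps change the same side of the carbonyl, an at least 1.6-fold higher number from compound 1 to compound 3 (0.21 log units; that floor lies within the scatter) and an at least 1.6-fold higher number from compound 1 to compound 2 (0.21 log units; that floor lies within the scatter), and both give floors only. A modest drop in the number is expected, towards compound 1 at 61000 nM. For compound 4 a further limit remains possible. The expected change is an at least 1.8-fold lower number from compound 3 to compound 4 (0.25 log units; that floor lies within the scatter). Compound 4 is estimated at 55000 nM, with an expected range of 20000 nM to 100000 nM.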

Compound 4, half-maximal inhibitory concentration: 34000 nM
Estimate against measurement, compound 4: 1.6-fold (0.21 log units) above, within the range that was stated.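

In this assay, for the compounds shown here, ethoxy on the carbonyl carbon gives an at least 2.9-fold lower number from compound 3 to compound 4 (0.46 log units; beyond the scatter) and an at least 2.9-fold lower number from compound 2 to compound 4 (0.46 log units; beyond the scatter), the first steps to lie beyond the scatter. Against (5-hydroxypentyl)amino, the same place shows a 1.8-fold lower number from compound 1 to compound 4 (0.25 log units; within the scatter), so compound 4 and compound 1 cannot be ordered. The two larger steps remain floors, resting on limits of the assay: the limit of > 100000 nM in this assay, at which 2 of the 4 values shown sit.

The change from bis(2-hydroxyethyl)amino to ethoxy removes the nitrogen and the hydroxyl groups together, leaving their contributions unseparated. Diethylamino or butoxy on the carbonyl carbon would bear on that question.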